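A few compounds are considered here, and "the series" means these few. Any claim that something is new, unique, unknown or untested is made for them only; others in the source may bear on it.

Measured so far:
- compound 1 `C=C1C(=O)O[C@H]2[C@H]1CC/C(COC(=O)Cn1cc(F)c(=O)n(Cc3ccc(F)cc3)c1=O)=C\CC[C@@]1(C)O[C@@H]21`: 2730 nM
- compound 2 `C=C1C(=O)O[C@H]2[C@H]1CC/C(COC(=O)Cn1cc(F)c(=O)n(Cc3ccc(F)cc3F)c1=O)=C\CC[C@@]1(C)O[C@@H]21`: 3670 nM

Both numbers come from a functional assay on Bel-7402 cells (Homo sapiens) for antiproliferative activity, read by MTT assay, with a stated time of 72 h; on this read-out lower numbers stand for stronger inhibition and higher numbers for weaker inhibition. For the measured compounds named here, compound 2 stands level with the only other measured compound, since the one available comparison is a 1.3-fold higher number from compound 1 to compound 2 (0.13 log units; within the scatter). That step puts a fluoro in place of hydrogen on an aromatic carbon.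

Compound 3 `C=C1C(=O)O[C@H]2[C@H]1CC/C(COC(=O)Cn1cc(F)c(=O)n(Cc3cc(F)ccc3F)c1=O)=C\CC[C@@]1(C)O[C@@H]21` has not yet been measured. It has the same atoms as compound 2, joined differently: 2,5-difluorophenyl in place of 2,4-difluorophenyl on a saturated chain carbon bound to an aromatic nitrogen. Only one fluoro pattern separates the two, and the rest of the molecule stays the same.

Going by the values given here, the single measured step from above is the only guide, and it is an indirect one. It adds a fluoro to the aromatic ring, whereas compound 3 keeps the count of fluoro groups and differs in their pattern. Among the compounds with values here, no measured pair yet shows such a change directly. With so small a measured step on this ring, no change beyond the scatter is expected in this assay.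

The estimated step is a 1.1-fold lower number from compound 2 to compound 3 (0.05 log units; within the scatter).

For compound 3 the expected value is 3300 nM, with an estimated range from 1600 nM to 6800 nM.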

Compound 3, half-maximal inhibitory concentration: 3060 nM
Beside the measured number, compound 3's estimate is 1.1-fold (0.03 log units) above it; low and high end bracket the measured number.
By their numbers in this assay, from the lowest: compounds 1, 3 and 2 (each within the scatter of the next).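

For the compounds shown here, replacing 2,4-difluorophenyl with 2,5-difluorophenyl on the saturated chain carbon bound to an aromatic nitrogen gives, in this assay, a 1.2-fold lower number from compound 2 to compound 3 (0.08 log units; within the scatter) and is the first direct test of where the fluoro groups sit on this phenyl ring, rather than how many there are. Set against the 4-fluorophenyl group, the same position gives a 1.1-fold higher number from compound 1 to compound 3 (0.05 log units; within the scatter) and so, among these three fluoro patterns, neither the pattern nor the count of fluoro groups produces a difference that this assay can separate from the usual scatter. Nothing available here bears on why these three compounds read alike.

On these data alone, all three compounds carry only fluoro on this phenyl ring, so it remains open whether a different kind of group there, such as methoxy, nitrile or an amine, would give a step beyond the scatter. As far as these compounds go, it also remains open whether a plain unsubstituted benzyl group, or a longer chain in place of the benzyl group, would read any differently in this assay at this position.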